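Replacing dimethoxyphenyl with trifluoromethoxyphenyl on the anilino nitrogen

The source may hold more compounds than are shown below. What is called first, only, known or untested is meant among the compounds shown, and "the series" means these compounds.

Compound 1, `COc1ccc(Nc2ncnc3cc(OC)c(OCCCCC(=O)Nc4ccc(S(N)(=O)=O)cc4)cc23)cc1`, gives 30200 nM in a functional assay on NCI-H1975 cells (Homo sapiens) for antiproliferative activity, read by MTT assay, with a stated time of 72 h; a lower number here means a stronger inhibitor, a higher number a weaker inhibitor.
Compound 2, `COc1ccc(Nc2ncnc3cc(OC)c(OCCCCC(=O)Nc4ccc(S(N)(=O)=O)cc4)cc23)cc1OC`, gives 9230 nM in this assay.

Compound 2 stands at the lower of the two numbers in this assay; the step of a 3.3-fold lower number from compound 1 to compound 2 (0.51 log units; beyond the scatter) separates it from compound 1. Compound 3, `COc1cc2ncnc(Nc3ccc(OC(F)(F)F)cc3)c2cc1OCCCCC(=O)Nc1ccc(S(N)(=O)=O)cc1`, differs from compound 2 by 4-(trifluoromethoxy)phenyl in place of 3,4-dimethoxyphenyl on a nitrogen on an aromatic ring. Among the measured compounds shown here, only one measured step bears on this change: the step of a 3.3-fold lower number from compound 1 to compound 2 (0.51 log units; beyond the scatter) showed that gaining a methoxy on that phenyl ring gave a stronger inhibitor, and compound 3 gives that methoxy up again. For the measured compounds named here, no measured compound carries a trifluoromethoxy group, so the effect of that replacement is unknown. Compound 3 is therefore expected to land somewhere between compound 2 and compound 1, with a modest weakening as the most likely outcome. Compound 3 is expected to give 16000 nM, within a range from 5000 nM to 45000 nM. This estimate means an expected step of a 1.7-fold higher number from compound 2 to compound 3 (0.24 log units; within the scatter).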

Compound 3, half-maximal inhibitory concentration: 8770 nM
Estimate against measurement, compound 3: 1.8-fold (0.26 log units) above, within the range that was stated.
By their numbers in this assay, from the lowest: compounds 3 and 2 (each within the scatter of the next); then compound 1.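

In this assay putting 4-(trifluoromethoxy)phenyl in place of 3,4-dimethoxyphenyl on the nitrogen gives a 1.1-fold lower number from compound 2 to compound 3 (0.02 log units; within the scatter), so these two groups cannot be told apart here. Putting trifluoromethyl in place of methyl on the oxygen of compound 1 gives a 3.4-fold lower number from compound 1 to compound 3 (0.54 log units; beyond the scatter), which shows that a second methoxy on this ring is not the only change among these compounds that goes with a lower number. Nothing available explains either step.

On these data alone, whether the position would accept a plain phenyl, or a ring carrying an amine or a carboxylic acid, remains open. As far as these compounds go, it is also open whether a longer chain on the oxygen, rather than a new group on the ring, would move the number further.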